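Removing one fluorine from a fluorinated alcohol chain

The source may hold more compounds than are shown below. What is called first, only, known or untested is meant among the compounds shown, and "the series" means these compounds.

Measured compounds in a physicochemical assay for lipophilicity, read by NMR; on this read-out higher numbers stand for higher lipophilicity and lower numbers for lower lipophilicity:
compound 1 `OCCC(F)(F)C(F)F` gives 0.66
compound 2 `OCCC(F)(F)C(F)(F)F` gives 1.3
compound 3 `OCCC(F)F` gives 0.04

Compound 1 stands second highest of the three. Two steps from it have been measured: a number 0.64 log units higher from compound 1 to compound 2 (beyond the scatter), and a number 0.62 log units lower from compound 1 to compound 3 (beyond the scatter), both beyond the scatter and of modest size. Compound 4 `OCCC(F)C(F)F` differs from compound 1 by hydrogen in place of fluoro on a saturated chain carbon bound to a fluorine atom and two saturated chain carbons. This change is the reverse in kind of the addition of fluoro seen from compound 1 to compound 2, though at a different carbon, and it removes less than the step to compound 3 did. A downward step beyond the scatter in this assay is therefore expected, somewhat smaller than either measured step. For compound 4 the estimate is 0.2, with a range from -0.15 to 0.55, which is expected to correspond to a number 0.46 log units lower from compound 1 to compound 4 (beyond the scatter).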

Compound 4, partition coefficient: 0.29
The estimate for compound 4 lay 0.09 log units below the measured number, within the range that was stated.
By their numbers in this assay, from the lowest: compounds 3 and 4 (each within the scatter of the next); then compound 1; then compound 2.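

At this position, on a saturated chain carbon bound to a fluorine atom and two saturated chain carbons, the first change measured in this assay gives a number 0.37 log units lower from compound 1 to compound 4 (beyond the scatter). Removing this single fluoro thus shifts the read-out beyond the scatter, and it leaves compound 4 within the scatter of compound 3. Nothing shown here gives a reason for this step.

Going by these compounds, whether the same replacement would shift the read-out similarly on a longer chain remains open. So does its outcome in a chain ending in an amine or a carboxylic acid.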